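A few compounds are considered here, and "the series" means these few. Any claim that something is new, unique, unknown or untested is made for them only; others in the source may bear on it.

Of the compounds shown here, two have been measured in an assay on HEK293 cells for displacement of a labelled ligand from NPC1-like intracellular cholesterol transporter 1 (Homo sapiens); a higher number here means a weaker inhibitor, a lower number a stronger inhibitor. Compound 1 `CC(C)(C)c1ccc(C(=O)N2CCC3(CC2)C(=O)N(CC(=O)NCCCCCNS(C)(=O)=O)CN3c2ccccc2)cc1` gives 5500 nM in this assay. Compound 2 `CC(C)(C)OC(=O)NCC1CCCN(C(=O)CN2CN(c3ccccc3)C3(CCN(C(=O)c4ccc(C(C)(C)C)cc4)CC3)C2=O)C1` gives 9500 nM in this assay, a value within the scatter of that of compound 1, so the two cannot be set in order; compound 1 simply holds the lower of the two numbers. For the measured compounds named here, no pair of measured compounds differs in one place, so no measured step is available to guide the next change.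

Compound 3 `CC(C)(C)c1ccc(C(=O)N2CCC3(CC2)C(=O)N(CC(=O)NCCCNS(C)(=O)=O)CN3c2ccccc2)cc1` remains to be measured in this assay. It differs from compound 1 in one place: methanesulfonamido in place of 2-(methanesulfonamido)ethyl on a saturated chain carbon, three bonds along the chain from an amide-type nitrogen. The chain between the amide-type nitrogen and the methanesulfonamido group is shorter in compound 3, with the same donor and acceptor count retained.

Going by the values given here, with no measured step of this kind, the expected change from compound 1 to compound 3 is a 1.1-fold higher number from compound 1 to compound 3 (0.04 log units; within the scatter), a step not expected to exceed the scatter in either direction. Compound 3 is therefore expected to give about 6000 nM in this assay, within a range of 2500 nM to 15000 nM.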

Compound 3, half-maximal inhibitory concentration: 10400 nM
The estimate for compound 3 lay 1.7-fold (0.24 log units) below the measured number; measured number inside the range.
By their numbers in this assay, from the lowest: compounds 1, 2 and 3 (each within the scatter of the next).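

For the compounds shown here, the series now has its only measured step in this assay: methanesulfonamido in place of 2-(methanesulfonamido)ethyl on a saturated chain carbon, three bonds along the chain from an amide-type nitrogen (a 1.9-fold higher number from compound 1 to compound 3 (0.28 log units; within the scatter)). The 5-(methanesulfonamido)pentyl chain of compound 1 and the 3-(methanesulfonamido)propyl chain of compound 3 therefore cannot be set in order, and no effect of chain length at this position can be read from this pair. Nothing available bears on the reason for this result.

As far as these compounds go, it remains open whether a longer chain than 5-(methanesulfonamido)pentyl, or the shorter (methanesulfonamido)methyl, would give a step beyond the scatter. Also open, from the compounds shown here alone, is how an amine or a carboxylic acid in place of the methanesulfonamido group would read on this chain.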